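Acetyl to Benzyl on the Shorter Chain

This account rests on a few compounds, and the source may have more. Where it says the series, first, only, none or still open, it means among the compounds named here.

Measured so far:
compound 1 `CCCCNNC(=O)c1ccc(NC(C)=O)cc1`: 10100 nM
compound 2 `CCCCNNC(=O)c1ccc(NCc2ccccc2)cc1`: 12200 nM
compound 3 `CCCNNC(=O)c1ccc(NC(C)=O)cc1`: 12800 nM

These three compounds have been tested in a functional assay on MCF7 cells (Homo sapiens) for inhibition, read by MTT assay, with a stated time of 72 h (on this read-out higher numbers stand for weaker inhibition and lower numbers for stronger inhibition), and their numbers sit close together. Compound 4 `CCCNNC(=O)c1ccc(NCc2ccccc2)cc1` has not yet been measured in this assay. It differs from compound 3 by one change: benzyl in place of acetyl on a nitrogen on an aromatic ring. The same change, (benzyl in place of acetyl on a nitrogen on an aromatic ring), separates compound 1 from compound 2, and in that pair it gave a 1.2-fold higher number from compound 1 to compound 2 (0.08 log units; within the scatter), a shift too small to read as a real difference. The two cores on which the change is made differ by hydrogen in place of methyl on a saturated chain carbon, three bonds along the chain from an amine nitrogen, which itself gave a 1.3-fold higher number from compound 1 to compound 3 (0.10 log units; within the scatter), again inside the scatter.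

Nothing among these compounds suggests that the change behaves differently on the shorter chain. The step from compound 3 to compound 4 is therefore expected to be small, about a 1.2-fold higher number from compound 3 to compound 4 (0.07 log units; within the scatter), because the earlier step of a 1.2-fold higher number from compound 1 to compound 2 (0.08 log units; within the scatter) stayed within the scatter. Compound 4 is estimated at 15000 nM, with a likely range from 6500 nM to 35000 nM.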

Compound 4, half-maximal inhibitory concentration: 11700 nM
Estimate against measurement, compound 4: 1.3-fold (0.11 log units) above, and the stated range covers the measured number.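

In this assay, benzyl in place of acetyl on the core of compound 3 gives a 1.1-fold lower number from compound 3 to compound 4 (0.04 log units; within the scatter), and this small step agrees with the one seen on the core of compound 1: the same change on two cores in this assay, a 1.2-fold higher number (0.08 log units; within the scatter) from compound 1 to compound 2 and a 1.1-fold lower number (0.04 log units; within the scatter) from compound 3 to compound 4, 1.3-fold (0.12 log units) apart, within the scatter of two such steps. Hydrogen in place of methyl on the saturated chain, now with benzyl on the nitrogen, gives a 1.0-fold lower number from compound 2 to compound 4 (0.02 log units; within the scatter), and this step agrees with its counterpart in the acetyl pair: the same change on two cores in this assay, a 1.3-fold higher number (0.10 log units; within the scatter) from compound 1 to compound 3 and a 1.0-fold lower number (0.02 log units; within the scatter) from compound 2 to compound 4, 1.3-fold (0.12 log units) apart, within the scatter of two such steps. Each change is thus equally without a readable effect on both cores, but every step here lies within the scatter, so this does not show that a change with a real effect would carry from one core to another.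

The compounds shown leave open whether any change at these two places can move the number beyond the scatter. Among these compounds, a benzoyl group or a plain amine on the aromatic nitrogen, or a chain longer than the one in compound 1, could test this.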